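A Chlorophenyl Rearrangement and Its Expected Effect

The compounds below may be only part of what the source reports. "The series", "measured", "known", "first", "only" and "open" are said of these compounds alone.

Compound 1, with the structure `CC(C(=O)N1CCN(c2ccc(Cl)cc2)CC1)N1C(=O)CCC1=O`, was examined in a functional assay on the whole organism (strain Swiss) with Mus musculus as the target, in the maximal electroshock model, with a stated time of 2 h, at a dose of 100 mg/kg by the intraperitoneal route (a lower number here means a weaker effect, a higher number a stronger effect of the compound at the dose given), where compound 1 gives 0%. Compound 2, `CCC(C(=O)N1CCN(c2cccc(C)c2)CC1)N1C(=O)CCC1=O`, stands level with it within the usual scatter: in this assay compound 2 gives 0%. Compound 1 therefore sits at the floor of the read-out, and no step beyond the scatter appears anywhere among the measured compounds. Compound 3, `CC(C(=O)N1CCN(c2cccc(Cl)c2)CC1)N1C(=O)CCC1=O`, has not yet been measured. It differs from compound 1 by 3-chlorophenyl in place of 4-chlorophenyl on an amine nitrogen in a ring. The two measured compounds give no sign that any change to the group on the amine nitrogen moves the read-out. The step is accordingly expected to be none beyond the scatter: no change at the digits printed from compound 1 to compound 3 (within the scatter). Compound 3 is estimated to give 0% in this assay, with an expected range from 0% to 25%.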

Compound 3, a percentage reported as activity, at one dose (the size of the read-out at that dose, not a potency): 0%
Estimate against measurement, compound 3: no gap at the digits printed; low and high end bracket the measured number.
By their numbers in this assay, from the lowest: compounds 1, 2 and 3 (each within the scatter of the next).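

In this assay, 3-chlorophenyl in place of 4-chlorophenyl on the amine nitrogen in a ring gives no change at the digits printed from compound 1 to compound 3 (within the scatter) and provides the first comparison among these compounds that differ in one place. Compound 1 and compound 3 both lie at the floor of the read-out, so neither placement of the chlorine produces a measurable effect at the dose given, and the pair cannot show whether this change would matter in a compound with a measurable effect. No evidence is available that bears on this result.

Going by these compounds, it remains open whether a methoxy or trifluoromethyl group in place of the chlorine would lift the read-out from the floor. On these data alone, the effect of a longer chain on the shared core also remains unknown.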